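Hydroxy to methoxy on the chlorophenyl arm of a pyrazole urea series

The source may report more compounds than this note shows. Statements on the series, on what has been measured and on what is new or still open speak of the compounds shown alone.

Measured so far in a functional assay on HCT-116 cells (Homo sapiens) for inhibition, read by sulforhodamine B assay, with a stated time of 48 h; on this read-out higher numbers stand for weaker inhibition and lower numbers for stronger inhibition:
compound 1 `O=C(Nc1cccc(-n2cc(-c3ccncc3)c(-c3cc(O)cc(Cl)c3)n2)c1)Nc1ccc(Cl)c(C(F)(F)F)c1` gives 1960 nM
compound 2 `O=C(Nc1cccc(-n2cc(-c3ccncc3)c(-c3cc(O)cc(Cl)c3)n2)c1)Nc1ccc(Cl)c(Cl)c1` gives 1740 nM

For the measured compounds named here, compound 1 carries the highest of the two numbers seen so far, but the only neighbour, compound 2, is a step of a 1.1-fold lower number from compound 1 to compound 2 (0.05 log units; within the scatter) away, so the two cannot be separated on the numbers alone. That step touches the aryl urea end of the molecule, not the phenol.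

Compound 3 `COc1cc(Cl)cc(-c2nn(-c3cccc(NC(=O)Nc4ccc(Cl)c(C(F)(F)F)c4)c3)cc2-c2ccncc2)c1` is the next point. It differs from compound 1 by methyl in place of hydrogen on an oxygen on an aromatic ring; the hydroxy of the 3-chloro-5-hydroxyphenyl becomes a methoxy, giving a 3-chloro-5-methoxyphenyl. Going by the values given here, no measured step in this assay touches that oxygen, so nothing in hand bears directly on the change. Among the compounds with values here, the one step that exists, from compound 1 to compound 2, sits on a different ring and was within the scatter.

Within the data shown here, with no guiding step, compound 3 is expected to stay close to compound 1, an estimated step of a 1.3-fold higher number from compound 1 to compound 3 (0.11 log units; within the scatter), with a wide range either way. The estimate for compound 3 in this assay is 2500 nM (range 700 nM to 9000 nM).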

Compound 3, half-maximal inhibitory concentration: 630 nM
Compound 3: the middle estimate sits 4.0-fold (0.60 log units) above what was measured, and the stated range ends above it.
By their numbers in this assay, from the lowest: compound 3; then compounds 2 and 1 (each within the scatter of the next).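

In this assay, for the compounds shown here, the methyl on the oxygen of the 3-chloro-5-hydroxyphenyl gives the first step that lies beyond the scatter, a move of a 3.1-fold lower number from compound 1 to compound 3 (0.49 log units; beyond the scatter) in the direction of stronger inhibition, whereas the earlier change on the aryl urea end, a 1.1-fold lower number from compound 1 to compound 2 (0.05 log units; within the scatter), could not be told from noise. This position therefore responds to substitution, and in this matched pair the free hydroxy is not required for inhibition, since the methoxy of compound 3 gives the lower number. No measurement on hand accounts for the gain, and it rests on this single pair.

Going by these compounds, whether the gain stops at methoxy or carries on to a longer chain such as ethoxy, or to an amine on the same aromatic carbon, remains open. Going by these compounds alone, it is also open whether the same hydroxy to methoxy step holds on the chloro-substituted urea end of compound 2, since the only reading so far comes with the trifluoromethyl partner.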